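The compounds below may be only part of what the source reports. "The series", "measured", "known", "first", "only" and "open" are said of these compounds alone.

Two compounds built on the same core have been examined in a functional assay on HOP-62 cells (Homo sapiens) for cytotoxicity, read by sulforhodamine B assay, with a stated time of 48 h; on this read-out lower numbers stand for higher toxicity in this test and higher numbers for lower toxicity in this test. Compound 1 `ClCc1cccc(Cn2cnc3ncnc(Cl)c32)c1` gives 7410 nM in this assay, and compound 2 `ClCc1cccc(Cn2cnc3c(Cl)ncnc32)c1` gives 10200 nM. Compound 1 holds the lowest of the two numbers, but its nearest neighbour, compound 2, lies within the scatter of it, so the pair cannot be separated on these data. Compound 3 `ClCc1cccc(Cn2cnc3nc(Cl)nc(Cl)c32)c1` is derived from compound 1 by a single change: chloro in place of hydrogen on an aromatic carbon. Going by the values given here, no step between two measured compounds in this set mirrors that change, so there is no measured precedent to lean on. Because compound 1 sits at 7410 nM and nothing in the set shows a chloro entering at such a place, the step from compound 1 to compound 3 is expected to be small, with no direction beyond the scatter, an expected 1.1-fold lower number from compound 1 to compound 3 (0.06 log units; within the scatter). For compound 3 the estimated value in this assay is 6500 nM, with an expected range from 2500 nM to 17000 nM.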

Compound 3, concentration lethal to 50% of the cells: 6020 nM
Estimate against measurement, compound 3: 1.1-fold (0.03 log units) above, and the stated range covers the measured number.
By their numbers in this assay, from the lowest: compounds 3, 1 and 2 (each within the scatter of the next).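

In this assay, chloro in place of hydrogen on an aromatic carbon, at the place between two ring nitrogen atoms, gives a 1.2-fold lower number from compound 1 to compound 3 (0.09 log units; within the scatter). Going by these compounds alone, this is the first step between measured compounds in the set, and it shows that a chloro group can stand at this position, on a ring that already carries a chloro group, without the number leaving the scatter around compound 1. A single heavy atom entering here therefore leaves the read-out unresolved from that of its parent.

From the compounds shown here alone, it remains open whether another group at this place, such as an amine, a methoxy group or a longer chain, would give a step beyond the scatter. Going by these compounds, it also remains open whether a chloro group here would give a similar step on a core without the other chloro group. Nothing among the available data offers an explanation for this result.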